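Amide in Place of Amine: Expected Effect on Kinase Inhibition

This account rests on a few compounds, and the source may have more. Where it says the series, first, only, none or still open, it means among the compounds named here.

Compound 1 `Cn1cc(C2=C(c3cccc4ccc(CN)cc34)C(=O)NC2=O)c2ccccc21` gives only a limit, > 316 nM, in an assay on isolated protein for inhibition of protein kinase C eta type (Homo sapiens), read by scintillation proximity assay and 33P incorporation, with a stated time of 60 min, in the presence of a further agent that is not named here; a higher number here means a weaker inhibitor, a lower number a stronger inhibitor. Compound 2 `CNCc1ccc2ccc(Cl)c(C3=C(c4cn(C)c5ccccc45)C(=O)NC3=O)c2c1` gives 34 nM in this assay. Compound 3 `COCCNCc1ccc2ccc(Cl)c(C3=C(c4cn(C)c5ccccc45)C(=O)NC3=O)c2c1` gives 206 nM in this assay.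

For the measured compounds named here, compound 3 thus has the higher of the two numbers known; the value of compound 1 is a limit (the limit of > 316 nM in this assay, at which 1 of the 3 values shown sits), not a number. Compound 4 `CC(=O)N(C)Cc1ccc2ccc(Cl)c(C3=C(c4cn(C)c5ccccc45)C(=O)NC3=O)c2c1` differs from compound 3 by acetyl(methyl)amino in place of (2-methoxyethyl)amino on a saturated chain carbon bound to an aromatic carbon. Going by the values given here, one measured step touches this part of the molecule: a 6.1-fold higher number from compound 2 to compound 3 (0.78 log units; beyond the scatter), showing that enlarging what sits on this amine nitrogen weakened inhibition. Compound 4 goes further, removing the amine hydrogen and the basic nitrogen altogether, so a further weakening is expected. Compound 4 is estimated at 1000 nM, within 250 nM to 4000 nM, meaning a 4.9-fold higher number from compound 3 to compound 4 (0.69 log units; beyond the scatter).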

Compound 4, half-maximal inhibitory concentration: > 316 nM
Compound 4: a limit, no number (the forecaster's own chance of this, stated with the estimate: 35%); the middle value does not contradict the limit.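

In this assay compound 4 gives only a limit, not a number: the limit of > 316 nM in this assay, at which 2 of the 4 values shown sit. Acetyl in place of hydrogen on the amine nitrogen clearly weakens inhibition (an at least 9.2-fold higher number from compound 2 to compound 4 (0.96 log units; beyond the scatter)), so this position does not accept every group of this size. The comparison with the (2-methoxyethyl)amino group is less firm (an at least 1.5-fold higher number from compound 3 to compound 4 (0.18 log units; that floor lies within the scatter)), and the order of compound 3 and compound 4 stays unsettled.

As far as these compounds go, how far compound 4 lies beyond its limit remains unknown. From the compounds shown here alone, what a dimethylamino group or a longer chain on this nitrogen would give also remains open.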